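The source may hold more compounds than are shown below. What is called first, only, known or untested is meant among the compounds shown, and "the series" means these compounds.

Compound 1 `COc1ccc(C(=O)NNc2c(Br)cccc2Br)cc1` gives > 100000 nM. Compound 2 `CCCOc1ccc(C(=O)NNc2c(Br)cccc2Br)cc1` gives > 100000 nM. Compound 3 `Cc1ccc(C(=O)NNc2c(Cl)cccc2Cl)cc1` gives > 100000 nM.

In a toxicity assay on MDCK cells (Canis lupus familiaris) for cytotoxicity, read by CCK-8 assay, with a stated time of 48 h (a lower number here means that less compound is tolerated, a higher number that more compound is tolerated), compound 1 gives only a limit, > 100000 nM, not a number. Compound 2 likewise gives only a limit in this assay, > 100000 nM. Compound 3 too gives only a limit in this assay, > 100000 nM. All three sit at the limit of > 100000 nM in this assay, at which 3 of the 3 values shown sit, so the step from compound 1 to compound 2, a step that the two limits leave unreadable from compound 1 to compound 2, cannot be read in size. That step is ethyl in place of hydrogen on a saturated chain carbon bound to an oxygen on an aromatic ring.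

Compound 4 `CCCc1ccc(C(=O)NNc2c(Cl)cccc2Cl)cc1` has not yet been measured in this assay. It differs from compound 3 by ethyl in place of hydrogen on a saturated chain carbon bound to an aromatic carbon. This is the same kind of change as that from compound 1 to compound 2, but not the same change: in the one case the place is on a saturated chain carbon bound to an oxygen on an aromatic ring, in the other on a saturated chain carbon bound to an aromatic carbon. How the core of compound 3 differs from the core of compound 1 is not broken down here.

For the measured compounds named here, because compound 3 sits at the limit of > 100000 nM in this assay, at which 3 of the 3 values shown sit, and the only step of this kind, from compound 1 to compound 2, is a step that the two limits leave unreadable from compound 1 to compound 2, compound 4 is expected to stay near that limit, a step of a number no higher from compound 3 to compound 4 (the limit leaves the size open). The estimate for compound 4 in this assay is 100000 nM, with a range from 40000 nM to 250000 nM.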

Compound 4, half-maximal cytotoxic concentration: > 100000 nM
Compound 4 was reported as a limit; the forecaster's own chance of this, stated with the estimate: 75%; the middle value sits exactly at the limit.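

In this assay, for the compounds shown here, compound 4 gives only a limit, > 100000 nM, as compound 3 does, so the step between compound 3 and compound 4 cannot be read in size and no new step emerges. All the compounds shown now stand at one place: the limit of > 100000 nM in this assay, at which 4 of the 4 values shown sit.

The compounds shown leave open what concentration of any of them is no longer tolerated, and whether lengthening either chain changes that concentration.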